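The source may report more compounds than this note shows. Statements on the series, on what has been measured and on what is new or still open speak of the compounds shown alone.

For the measured compounds named here, compound 2 `Cc1cc(-c2cccc(C#N)c2)cc(C)c1Nc1ccnc(Nc2ccc(C#N)cc2)n1` gives 920 nM in an ADME assay on MT4 cells (Homo sapiens) for cytotoxicity, read by MTT assay, with a stated time of 4 days (a higher number here means that more compound is tolerated, a lower number that less compound is tolerated), the lowest of the three numbers known so far. Compound 1 `Cc1cc(-c2cccc(C(F)(F)F)c2)cc(C)c1Nc1ccnc(Nc2ccc(C#N)cc2)n1` gives 4030 nM, and compound 3 `Cc1cc(-c2ccccc2Cl)cc(C)c1Nc1ccnc(Nc2ccc(C#N)cc2)n1` gives 3990 nM. Compound 4 `Cc1ccccc1-c1cc(C)c(Nc2ccnc(Nc3ccc(C#N)cc3)n2)c(C)c1` differs from compound 2 by 2-methylphenyl in place of 3-cyanophenyl on an aromatic carbon. Going by the values given here, two measured steps bear on this change, each setting the 3-cyanophenyl against a ring that carries no nitrile: a 4.4-fold lower number from compound 1 to compound 2 (0.64 log units; beyond the scatter) and a 4.3-fold higher number from compound 2 to compound 3 (0.64 log units; beyond the scatter). In both, the ring without the nitrile sits at the higher number, so a modest rise is expected for the step of a 3.8-fold higher number from compound 2 to compound 4 (0.58 log units; beyond the scatter). Compound 4 is therefore estimated at 3500 nM, with a likely range from 1200 nM to 10000 nM.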

Compound 4, half-maximal cytotoxic concentration: 3820 nM
For compound 4 the middle estimate is 1.1-fold (0.04 log units) below the measured one; measured number inside the range.
By their numbers in this assay, from the lowest: compound 2; then compounds 4, 3 and 1 (each within the scatter of the next).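

A third ring without a nitrile, 2-methylphenyl, again sits apart from 3-cyanophenyl (a 4.2-fold higher number from compound 2 to compound 4 (0.62 log units; beyond the scatter)), leaving compound 2 alone at the low end in this assay. Methyl and chloro on this ring cannot be told apart (a 1.0-fold lower number from compound 3 to compound 4 (0.02 log units; within the scatter)), nor can 2-methylphenyl and 3-(trifluoromethyl)phenyl (a 1.1-fold lower number from compound 1 to compound 4 (0.02 log units; within the scatter)), so three different rings without a nitrile now share one level. Nothing here gives a cause for the gap between these rings and 3-cyanophenyl. Still open, on these data alone, is where a ring carrying an amine or a carboxylic acid would fall: with compound 2 or with the other three.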